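The source may report more compounds than this note shows. Statements on the series, on what has been measured and on what is new or still open speak of the compounds shown alone.

Measured so far:
- compound 1 `O=C(/C=C\c1ccc([N+](=O)[O-])cc1)N1N=C(c2ccncc2)OC1c1c[nH]c2ccccc12` — > 30 ug/mL, a limit of the assay
- compound 2 `O=C(/C=C\c1cccc(Cl)c1)N1N=C(c2ccncc2)OC1c1c[nH]c2ccccc12` — > 30 ug/mL, a limit of the assay

Compound 2 stands only at a limit in an ADME assay on A549 cells (Homo sapiens) for cytotoxicity, read by MTT assay, with a stated time of 48 h (a higher number here means a weaker inhibitor of growth, a lower number a stronger inhibitor of growth), with no number beneath it. Compound 1 likewise gives only a limit in this assay. The step that the two limits leave unreadable from compound 1 to compound 2 is therefore unreadable; note (the limit of > 30 ug/mL in this assay, at which 2 of the 2 values shown sit).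

Compound 3 `O=C(/C=C\c1ccc(Cl)cc1)N1N=C(c2ccncc2)OC1c1c[nH]c2ccccc12` differs from compound 2 by 4-chlorophenyl in place of 3-chlorophenyl on a double-bonded chain carbon bound to a double-bonded chain carbon. Going by the values given here, the one measured step bears on this change only in that both ends sit at the limit, so no step of readable size is expected in this assay; a further limit is the likeliest outcome.

Compound 3 is expected at 40 ug/mL (range 15 ug/mL to 100 ug/mL). The estimated step that the limit leaves unreadable from compound 2 to compound 3 is expected to have no readable size.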

Compound 3, concentration for 50% growth inhibition: > 30 ug/mL
Compound 3: no number, only a limit; the forecaster's own chance of this, stated with the estimate: 75%; the middle value lies beyond the limit too.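

Compound 3, like compound 1 and compound 2, gives only a limit in this assay, so no step among the three can be read: the limit of > 30 ug/mL in this assay, at which 3 of the 3 values shown sit.

The compounds shown leave open whether 3-chlorophenyl, 4-chlorophenyl or 4-nitrophenyl on the shared core makes any difference in this assay.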